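Meta-aryl substituent series: chloro replacing methyl

The source may hold more compounds than are shown below. What is called first, only, known or untested is meant among the compounds shown, and "the series" means these compounds.

Compound 3 `CC1=NC(C)=C(C(=O)O)C(c2cccc(C)c2)/C1=C(\O)OC/C=C/c1ccccc1` stands at the low end of the numbers seen so far in a functional assay on thoracic aorta for inhibition of Voltage-gated L-type calcium channel (Rattus norvegicus) (on this read-out higher numbers stand for weaker inhibition and lower numbers for stronger inhibition), where compound 3 gives 76 nM. Compound 1 `COC(=O)c1cccc(C2C(C(=O)O)=C(C)N=C(C)/C2=C(/O)OC/C=C/c2ccccc2)c1` in this assay gives 4400 nM. Compound 2 `CC1=NC(C)=C(C(=O)O)C(c2cccc(C(=O)O)c2)/C1=C(\O)OC/C=C/c1ccccc1` in this assay reaches only the limit of the assay, > 10000 nM, a limit rather than a number, matching (the limit of > 10000 nM in this assay, at which 1 of the 3 values shown sits). The step of a 58-fold lower number from compound 1 to compound 3 (1.76 log units; beyond the scatter) and the step of an at least 130-fold lower number from compound 2 to compound 3 (2.11 log units; beyond the scatter) show that the group on the aryl ring weighs heavily on the read-out, while an at least 2.2-fold higher number from compound 1 to compound 2 (0.35 log units; beyond the scatter) is a smaller shift.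

Compound 4 `CC1=NC(C)=C(C(=O)O)C(c2cccc(Cl)c2)/C1=C(\O)OC/C=C/c1ccccc1` differs from compound 3 by chloro in place of methyl on an aromatic carbon, that is, from 3-methylphenyl to 3-chlorophenyl, placed meta to a large group. Within the data shown here, no measured step carries a chloro at that position, so the two large steps into compound 3 give only the sense that this position is sensitive, not the direction for chloro. Both groups are single heavy atoms without donors or acceptors, so the change from compound 3 to compound 4 is expected to be a 1.5-fold lower number from compound 3 to compound 4 (0.18 log units; within the scatter), no more than modest and likely within the scatter. Compound 4 is therefore estimated at 50 nM in this assay, with a range from 15 nM to 200 nM.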

Compound 4, half-maximal inhibitory concentration: 20 nM
The estimate for compound 4 lay 2.5-fold (0.40 log units) above the measured number, and the stated range covers the measured number.
By their numbers in this assay, from the lowest: compound 4; then compound 3; then compound 1. At a limit, above all of these: compound 2.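

Of the groups shown at this position in this assay, chloro gives the lowest number, so methyl does not mark the low end of the series: the exchange gives a 3.8-fold lower number from compound 3 to compound 4 (0.58 log units; beyond the scatter). The position therefore separates even two groups that match in heavy-atom count and carry no hydrogen-bond donors or acceptors, not only these small groups from the larger methoxycarbonyl, where the comparison gives a 220-fold lower number from compound 1 to compound 4 (2.34 log units; beyond the scatter). Compound 2 remains a limit and not a number, so an at least 500-fold lower number from compound 2 to compound 4 (2.69 log units; beyond the scatter) is a bound on the step rather than its size: the limit of > 10000 nM in this assay, at which 1 of the 4 values shown sits.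

The compounds shown leave open whether the lower number is particular to chloro or extends to other halogens such as fluoro or bromo, and how a methoxy group or an amine at this position would compare. They also leave open whether the same order of chloro and methyl holds elsewhere on the aromatic ring, or with a different group on the rest of the shared core.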